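The source may hold more compounds than are shown below. What is called first, only, known or untested is meant among the compounds shown, and "the series" means these compounds.

Measured compounds:
Compound 1 `CC(=O)NCCN(C)c1cccc(OCCCCN)c1` gives 0.32 in a functional assay on cells for agonist activity at melatonin receptor type 1A (Homo sapiens), read by GTPgammaS binding, with a stated time of 30 min; a higher number here means a larger maximal response, a lower number a smaller maximal response.
Compound 2 `CC(=O)NCCN(C)c1cccc(OCCCCCCNC(=O)Oc2cccc(-c3ccccc3)c2)c1` gives 0.7 in this assay.

Compound 2 stands highest of the two, with compound 1 lower by a gap beyond the scatter. The step under consideration leads to compound 3 `CC(=O)NCCN(C)c1cccc(OCCCCCCNC(=O)Oc2cccc(-c3cccc(C(N)=O)c3)c2)c1`, which differs from compound 2 in one place: carbamoyl in place of hydrogen on an aromatic carbon. Within the data shown here, no measured pair shows this change, so its effect is unknown. The account expects a small shift, a number 0.050 lower from compound 2 to compound 3 (within the scatter), within the scatter in this assay. Compound 3 is therefore estimated at 0.65, with a range from 0.4 to 0.9.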

Compound 3, intrinsic activity: the largest response reached, as a fraction of the reference agonist's: 0.79
Estimate against measurement, compound 3: 0.14 below; the range from low to high includes it.
By their numbers in this assay, from the lowest: compound 1; then compounds 2 and 3 (each within the scatter of the next).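

In this assay the change from phenyl to 3-carbamoylphenyl gives a number 0.090 higher from compound 2 to compound 3 (within the scatter), so this aromatic carbon carries carbamoyl with no shift in maximal response that can be told from the scatter. Before compound 3, this position had been read only with hydrogen, in compound 2. Nothing shown gives a reason for this result. Still open, going by these compounds, is whether a carboxylic acid or an amine on the same carbon would read alike. Also open, on these data alone, is how carbamoyl would read on another carbon of that ring.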